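A few compounds are considered here, and "the series" means these few. Any claim that something is new, unique, unknown or untested is made for them only; others in the source may bear on it.

Of the compounds shown here, three of one shared core have been tested in a physicochemical assay for solubility; a lower number here means a less soluble compound, a higher number a more soluble compound. Compound 1 `O=C(O)c1ccc(C(=O)/C(=C\c2ccc([N+](=O)[O-])c(F)c2)SCc2ccc(Br)cc2)cc1` gives < 1000 ug/mL, which is a limit of the assay rather than a number. Compound 2 `Cc1ccc(CS/C(=C/c2ccc(F)c([N+](=O)[O-])c2)C(=O)c2ccc(C(=O)O)cc2)cc1` also gives < 1000 ug/mL, again a limit. Compound 3 `O=C(O)c1ccc(C(=O)/C(=C\c2ccc(Br)c([N+](=O)[O-])c2)SCc2ccc(F)cc2)cc1` gives < 1000 ug/mL, a limit as well. For the measured compounds named here, the picture is therefore uniform: the limit of < 1000 ug/mL in this assay, at which 3 of the 3 values shown sit, so no compound can be placed above or below another, and the true distance between them is unknown. Compound 4 `O=C(O)c1ccc(C(=O)/C(=C\c2cc([N+](=O)[O-])ccc2F)SCc2ccc(Br)cc2)cc1` has not yet been measured. It keeps the same atoms as compound 1, joined differently: 2-fluoro-5-nitrophenyl in place of 3-fluoro-4-nitrophenyl on a double-bonded chain carbon bound to a double-bonded chain carbon. Going by the values given here, no step between measured compounds is available, and this exchange of one fluoronitrophenyl group for the other gives no ground to expect a change beyond the usual scatter in this assay. The expected step is a step that the limit leaves unreadable from compound 1 to compound 4, that is, none beyond the scatter. Compound 4 is thus expected to give about 300 ug/mL, within a range from 30 ug/mL to 1000 ug/mL, and most probably the same limit once more.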

Compound 4, solubility: < 1000 ug/mL
Compound 4 gave a limit, no number; the forecaster's own chance of this, stated with the estimate: 85%; the middle value does not contradict the limit.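

Compound 4 gives < 1000 ug/mL, which is a limit and not a number, so no step from compound 1 to compound 4 can be read: the limit of < 1000 ug/mL in this assay, at which 4 of the 4 values shown sit.

The compounds shown leave open what their true values in this assay are, and whether 2-fluoro-5-nitrophenyl and 3-fluoro-4-nitrophenyl differ there at all.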